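A Longer Chain on the Second Chlorinated Core

A few compounds are considered here, and "the series" means these few. Any claim that something is new, unique, unknown or untested is made for them only; others in the source may bear on it.

Compound 1 `CCCCC(=O)ON1C(=O)COc2ccc(Cl)cc21`: 26600 nM
Compound 2 `CCC(=O)ON1C(=O)COc2c(Cl)cccc21`: 1300000 nM
Compound 3 `CCC(=O)ON1C(=O)COc2ccc(Cl)cc21`: 46600 nM

Three compounds have been run in an ADME assay on the whole organism for inhibition, with Triticum aestivum as the target, with a stated time of 5 days; on this read-out lower numbers stand for stronger inhibition and higher numbers for weaker inhibition. Compound 1 and compound 3 share one core and differ only in the chain attached to it: ethyl in place of hydrogen on a saturated chain carbon, two bonds along the chain from a carbonyl carbon. In this assay this change gave a 1.8-fold lower number from compound 3 to compound 1 (0.24 log units; within the scatter), so the two values cannot be told apart with confidence.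

Compound 2 carries the same chain as compound 3, but its chlorine sits on another spot of the core; the two have the same atoms joined differently, and the difference between the two cores is not broken down here. In this assay compound 2 gives 1300000 nM, the highest number of the three, while compound 3 gives 46600 nM and compound 1 gives 26600 nM; both of these gaps lie well beyond the usual scatter.

Compound 4 `CCCCC(=O)ON1C(=O)COc2c(Cl)cccc21` has not yet been measured. It arises from compound 2 by ethyl in place of hydrogen on a saturated chain carbon, two bonds along the chain from a carbonyl carbon, the same change, at the same place, as that from compound 3 to compound 1. Among the measured compounds shown here, the step from compound 2 to compound 4 is therefore expected to be a 1.6-fold lower number from compound 2 to compound 4 (0.21 log units; within the scatter), which rests on the single earlier example, a 1.8-fold lower number from compound 3 to compound 1 (0.24 log units; within the scatter), and on the assumption that the change behaves alike on the second core. Compound 4 is thus estimated at 800000 nM in this assay, expected to fall between 250000 nM and 2500000 nM.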

Compound 4, half-maximal inhibitory concentration: 1640000 nM
The estimate for compound 4 lay 2.1-fold (0.31 log units) below the measured number, within the range that was stated.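

The new step in this assay is a 1.3-fold higher number from compound 2 to compound 4 (0.10 log units; within the scatter), so on this core, as on the core of compound 1, ethyl in place of hydrogen at this place on the chain gives no difference that can be told from the usual scatter. Set side by side, the two steps agree within that scatter, so in these two cases the change carries over from one core to the other in the plain sense that it has no readable effect on either: the same change on two cores in this assay, a 1.8-fold lower number (0.24 log units; within the scatter) from compound 3 to compound 1 and a 1.3-fold higher number (0.10 log units; within the scatter) from compound 2 to compound 4, 2.2-fold (0.34 log units) apart, within the scatter of two such steps. This does not show that the change has a real effect of any size or direction on either core, the opposite signs of the two steps carry no weight, and two pairs are too few to predict how the change would behave on any further core.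

The compounds shown leave open whether a chain longer than butyl, a branched chain, or a chain ending in an amine or a carboxylic acid would shift the number beyond the scatter. They also leave open what fluorine or bromine in place of the chlorine would do on either core.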